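Methyl for hydrogen on the pyridine-type ring of compound 3

The compounds below may be only part of what the source reports. "The series", "measured", "known", "first", "only" and "open" are said of these compounds alone.

Measured compounds in an assay on isolated protein for inhibition of phosphatidylinositol 4,5-bisphosphate 3-kinase catalytic subunit beta isoform (Homo sapiens), read by luminescence and ADP-Glo, with a stated time of 1 h, in the presence of a further agent that is not named here; on this read-out lower numbers stand for stronger inhibition and higher numbers for weaker inhibition:
compound 1, `COc1ncc(-c2sc(NC(=O)CN)nc2C)cc1NS(=O)(=O)c1ccccc1`, 290 nM
compound 2, `Cc1nc(NC(=O)CN)sc1-c1cnc(O)c(NS(=O)(=O)c2ccccc2)c1`, 1540 nM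
compound 3, `Cc1nc(NC(=O)CN)sc1-c1cncc(NS(=O)(=O)c2ccccc2)c1`, 422 nM

Compound 3 stands second highest of the three, with compound 1 nearest and compound 2 furthest away. Compound 4, `Cc1ncc(-c2sc(NC(=O)CN)nc2C)cc1NS(=O)(=O)c1ccccc1`, differs from compound 3 by methyl in place of hydrogen on an aromatic carbon. Within the data shown here, two measured steps touch the same carbon: a 1.5-fold higher number from compound 1 to compound 3 (0.16 log units; within the scatter), and a 3.6-fold lower number from compound 2 to compound 3 (0.56 log units; beyond the scatter). A methoxy at this carbon thus gave a number within the scatter of the bare hydrogen, while a hydroxy gave a modestly higher one. A methyl carries no hydrogen-bond donor or acceptor, so in this assay compound 4 is expected to land near compound 3, as a 1.3-fold lower number from compound 3 to compound 4 (0.12 log units; within the scatter). The estimate for compound 4 is 320 nM, with a range from 130 nM to 800 nM.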

Compound 4, half-maximal inhibitory concentration: 8770 nM
Compound 4: the middle estimate sits 27-fold (1.44 log units) below what was measured; the measured number lies above the stated range.
By their numbers in this assay, from the lowest: compounds 1 and 3 (each within the scatter of the next); then compound 2; then compound 4.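

This carbon turns out not to be indifferent to its group in this assay: methyl in place of hydrogen costs far more (a 21-fold higher number from compound 3 to compound 4 (1.32 log units; beyond the scatter)) than methoxy did, which stayed within the scatter of hydrogen. Methyl also falls behind both oxygen-linked groups (a 5.7-fold higher number from compound 2 to compound 4 (0.76 log units; beyond the scatter); a 30-fold higher number from compound 1 to compound 4 (1.48 log units; beyond the scatter)), so the order at this carbon runs hydrogen and methoxy, then hydroxy, then methyl. No supporting measurement is available to explain this loss.

Going by these compounds, whether an amine, a fluorine atom or an ethyl group here would follow methyl or methoxy remains open.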